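From Anilide to Piperidine Amide in a Glutathione Transferase Series

This account rests on a few compounds, and the source may have more. Where it says the series, first, only, none or still open, it means among the compounds named here.

Of the compounds shown here, three sharing one core have been measured in an assay on isolated protein for inhibition of glutathione S-transferase P (Homo sapiens), with a stated time of 10 min; a higher number here means a weaker inhibitor, a lower number a stronger inhibitor. Compound 1 `O=C(CCC(=O)OCCCCCCSc1ccc([N+](=O)[O-])c2nonc12)Nc1ccccc1Cl` gives 15500 nM. Compound 2 `Cc1ccccc1NC(=O)CCC(=O)OCCCCCCSc1ccc([N+](=O)[O-])c2nonc12` gives 4100 nM, and compound 3 `O=C(CCC(=O)OCCCCCCSc1ccc([N+](=O)[O-])c2nonc12)Nc1ccc(Br)cc1` gives 5090 nM. The steps among them are modest: a 3.8-fold lower number from compound 1 to compound 2 (0.58 log units; beyond the scatter) and a 3.0-fold lower number from compound 1 to compound 3 (0.48 log units; beyond the scatter) lie beyond the scatter, while a 1.2-fold higher number from compound 2 to compound 3 (0.09 log units; within the scatter) does not. Compound 3 therefore stands as the second highest number of the three, close to compound 2 and well below compound 1.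

Compound 4 `O=C(CCC(=O)N1CCCCC1)OCCCCCCSc1ccc([N+](=O)[O-])c2nonc12` has not yet been measured in this assay. It differs from compound 3 in one place: piperidin-1-yl in place of (4-bromophenyl)amino on a carbonyl carbon. This exchange takes away the six-membered aromatic ring with its one hydrogen-bond donor and puts in a six-membered non-aromatic ring with one hetero atom.

For the measured compounds named here, none of the measured steps bears directly on this change, since each of them swaps one aromatic ring for another or one substituent on such a ring for another. Those swaps moved the numbers only modestly, but the change here is of a different kind, so the expectation carries wider uncertainty. The estimated step is a 1.8-fold higher number from compound 3 to compound 4 (0.25 log units; within the scatter). Compound 4 is thus expected to show 9000 nM, with a range from 2500 nM to 35000 nM.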

Compound 4, half-maximal inhibitory concentration: 500 nM
Compound 4: the middle estimate sits 18-fold (1.26 log units) above what was measured; measured number below the stated range.
By their numbers in this assay, from the lowest: compound 4; then compounds 2 and 3 (each within the scatter of the next); then compound 1.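

In this assay, putting piperidin-1-yl on the carbonyl carbon gives a 10-fold lower number from compound 3 to compound 4 (1.01 log units; beyond the scatter), and the same kind of exchange gives an 8.2-fold lower number from compound 2 to compound 4 (0.91 log units; beyond the scatter) and a 31-fold lower number from compound 1 to compound 4 (1.49 log units; beyond the scatter), which makes compound 4 the strongest inhibitor of the four. The earlier compounds shown here all carried a six-membered aromatic ring on an amide nitrogen, so they could not show that this position accepts a non-aromatic ring with no amide hydrogen, or that neither the aromatic ring nor that hydrogen is needed for inhibition. For the compounds shown here, no measurement at hand explains why this exchange lowers the number so far.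

Going by these compounds, the aromatic ring and the amide hydrogen leave together in this change, so their separate contributions remain unknown, and cyclohexylamino, which pairs a non-aromatic ring with an amide hydrogen, would pull the two apart. On these data alone, it also remains open whether the ring itself matters or only the fully substituted amide nitrogen, a question that diethylamino, with two open chains, or morpholin-4-yl, with an added ring oxygen, could begin to answer.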